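This account rests on a few compounds, and the source may have more. Where it says the series, first, only, none or still open, it means among the compounds named here.

Measured so far:
compound 1 `Nc1cc(N)c2nc(-c3ccccc3)c(Sc3ccc(F)cc3)nc2c1`: 81300 nM
compound 2 `COc1cc(CNc2nc3cc(N)cc(N)c3nc2-c2ccccc2)cc(OC)c1OC`: 3020 nM
compound 3 `CCOC(=O)[C@H](CCC(=O)O)NC(=O)c1ccc(CNc2nc3cc(N)cc(N)c3nc2-c2ccccc2)cc1`: < 100000 nM, a limit of the assay rather than a number

In a functional assay on RPMI8266 cells (Homo sapiens) for inhibition, read by sulforhodamine B assay, with a stated time of 48 h (on this read-out lower numbers stand for stronger inhibition of growth and higher numbers for weaker inhibition of growth), compound 1 gives 81300 nM, the highest of the two numbers shown, while compound 2 gives 3020 nM. For compound 3 only a limit of the assay is reported, < 100000 nM; (the limit of < 100000 nM in this assay, at which 1 of the 3 values shown sits). Compound 4 `Nc1cc(N)c2nc(-c3ccccc3)c(NCc3ccc(F)cc3)nc2c1` differs from compound 1 in one place: (4-fluorobenzyl)amino in place of (4-fluorophenyl)sulfanyl on an aromatic carbon. Within the data shown here, no measured step covers such a change, so the expectation rests on compound 2, whose value of 3020 nM shows that a benzylamino group at this position can go with a much lower number than compound 1. Compound 4 is therefore expected to take a step of a 14-fold lower number from compound 1 to compound 4 (1.13 log units; beyond the scatter), towards stronger inhibition of growth. The estimate for compound 4 is 6000 nM, within a range from 1500 nM to 30000 nM.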

Compound 4, concentration for total growth inhibition: 6310 nM
Estimate against measurement, compound 4: 1.1-fold (0.02 log units) below; the range from low to high includes it.
By their numbers in this assay, from the lowest: compound 2; then compound 4; then compound 1.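

With the rest of the molecule unchanged, this position now has a direct comparison: in this assay, (4-fluorobenzyl)amino in place of (4-fluorophenyl)sulfanyl gives a 13-fold lower number from compound 1 to compound 4 (1.11 log units; beyond the scatter), towards stronger inhibition of growth. The swap removes sulfur, brings in nitrogen with one more carbon and adds a hydrogen-bond donor, so the step belongs to the whole group, not to any one of these parts. Nothing measured here explains the step. Still open, going by these compounds, is how a (4-fluorophenyl)amino group, with nitrogen but no added carbon, would compare, and whether a longer chain would go further.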